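Methoxy in place of hydrogen on the 2-phenylethenyl amide

A few compounds are considered here, and "the series" means these few. Any claim that something is new, unique, unknown or untested is made for them only; others in the source may bear on it.

Compound 3 `CN1[C@@H]2c3[nH]c4ccccc4c3C[C@H]1[C@H](C#N)N1[C@@H](CNC(=O)/C=C/c3ccccc3)c3[nH]c4ccccc4c3C[C@@H]21` holds the lower of the two numbers in hand in a functional assay on A2780 cells (Homo sapiens) for cytotoxicity, read by MTT assay, with a stated time of 72 h; a lower number here means a stronger inhibitor, a higher number a weaker inhibitor: compound 3 gives 770 nM. Compound 1 `CN1[C@@H]2c3[nH]c4ccccc4c3C[C@H]1[C@H](C#N)N1[C@@H](CNC(=O)c3ccc4ccccc4c3)c3[nH]c4ccccc4c3C[C@@H]21`, with naphthalen-2-yl on the carbonyl carbon, gives 1030 nM, and the step of a 1.3-fold lower number from compound 1 to compound 3 (0.13 log units; within the scatter) stays within the scatter. Compound 2 `CN1[C@@H]2c3[nH]c4ccccc4c3C[C@H]1[C@H](C#N)N1[C@@H](CNC(=O)/C=C/c3cccc(C(F)(F)F)c3)c3[nH]c4ccccc4c3C[C@@H]21` reaches only the limit > 10000 nM. Compound 4 `COc1ccc(/C=C/C(=O)NC[C@H]2c3[nH]c4ccccc4c3C[C@H]3[C@H]4c5[nH]c6ccccc6c5C[C@@H]([C@H](C#N)N23)N4C)cc1` differs from compound 3 by methoxy in place of hydrogen on an aromatic carbon. Going by the values given here, the one measured step on the same six-membered ring is an at least 12-fold lower number from compound 2 to compound 3 (1.11 log units; beyond the scatter), so a substituent there has moved the number, with the limit of > 10000 nM in this assay, at which 1 of the 3 values shown sits, on the weaker side. Methoxy is not trifluoromethyl, and no second aryl substituent has been measured, so the expected step of a 1.6-fold higher number from compound 3 to compound 4 (0.19 log units; within the scatter) is small, within the scatter or slightly weaker. Compound 4 is estimated at 1200 nM, range 400 nM to 5000 nM.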

Compound 4, half-maximal inhibitory concentration: 860 nM
Compound 4: middle estimate off by 1.4-fold (0.14 log units), on the high side; measured number inside the range.
By their numbers in this assay, from the lowest: compounds 3, 4 and 1 (each within the scatter of the next). At a limit, above all of these: compound 2.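

In this assay, methoxy on the aromatic ring para to a large group leaves the number within the scatter: a 1.1-fold higher number from compound 3 to compound 4 (0.05 log units; within the scatter). A substituent on this ring therefore does not by itself bring the loss seen with 3-(trifluoromethyl)phenyl, as an at least 11-fold lower number from compound 2 to compound 4 (1.06 log units; beyond the scatter) shows. The 2-(4-methoxyphenyl)ethenyl amide also stays within the scatter of the naphthalen-2-yl amide: a 1.2-fold lower number from compound 1 to compound 4 (0.08 log units; within the scatter).

Compound 2 remains a limit rather than a number: the limit of > 10000 nM in this assay, at which 1 of the 4 values shown sits. Open, on these data alone, are whether that loss follows the trifluoromethyl group or its place on the ring, and how an amine or a carboxylic acid there would read.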